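Adding a Cyanosulfanyl Group to a Weakly Cytotoxic Compound

The source may report more compounds than this note shows. Statements on the series, on what has been measured and on what is new or still open speak of the compounds shown alone.

Compound 1 `O=c1oc2ccccc2cc1-c1cn2nc(Cc3ccc(Cl)cc3)sc2n1` was tested in a functional assay on L1210 cells (Mus musculus) for cytotoxicity, with a stated time of 48 h; on this read-out higher numbers stand for weaker inhibition and lower numbers for stronger inhibition. For compound 1 only a limit is reported, > 10000 nM, which marks the boundary of the assay rather than a number (the limit of > 10000 nM in this assay, at which 1 of the 3 values shown sits). Two related compounds built on the shared core were measured as well: compound 2 `O=Cc1c(-c2ccc(F)cc2)nc2sc(Cc3ccc(Cl)cc3)nn12` gives 20000 nM and compound 3 `O=Cc1c(-c2ccc([N+](=O)[O-])cc2)nc2sc(Cc3ccc(Cl)cc3)nn12` gives 15000 nM. Within the data shown here, the single measured step, a 1.3-fold lower number from compound 2 to compound 3 (0.12 log units; within the scatter), lies within the scatter and concerns a different position. Compound 4 `N#CSc1c(-c2cc3ccccc3oc2=O)nc2sc(Cc3ccc(Cl)cc3)nn12` differs from compound 1 by cyanosulfanyl in place of hydrogen on an aromatic carbon. Among the measured compounds shown here, no measured step bears on this group, so no move beyond the scatter is expected. The expected step is a step that the limit leaves unreadable from compound 1 to compound 4. Compound 4 is therefore estimated at 15000 nM, between 5000 nM and 50000 nM.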

Compound 4, half-maximal inhibitory concentration: 1300 nM
The estimate for compound 4 lay 12-fold (1.06 log units) above the measured number; the measured number lies below the stated range.
By their numbers in this assay, from the lowest: compound 4; then compounds 3 and 2 (each within the scatter of the next).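

Cyanosulfanyl in place of hydrogen on this aromatic carbon moves the read-out in this assay, giving an at least 7.6-fold lower number from compound 1 to compound 4 (0.88 log units; beyond the scatter). It is the only step shown that lies beyond the scatter, and it shows that this position can respond to a change, which the step between compound 2 and compound 3, at a different position, did not show. Its full size cannot be read, as compound 1 stands at a limit and not at a number: the limit of > 10000 nM in this assay, at which 1 of the 4 values shown sits.

As far as these compounds go, whether a nitrile or a methylthio group on this carbon would give a number like that of compound 4 stays open. So does whether the sulfur or the nitrile part of cyanosulfanyl matters more.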